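Working notes on cytotoxicity across the shared-core amine series

The compounds below may be only part of what the source reports. "The series", "measured", "known", "first", "only" and "open" are said of these compounds alone.

Among the compounds with values here, compound 2 `Cc1ccc2[nH]c(=O)c(CN(Cc3ccc(O)cc3)Cc3ccc(C(C)(C)C)cc3)cc2c1` is the only compound with a number in a toxicity assay on MDCK cells (Canis lupus familiaris) for cytotoxicity, read by crystal violet staining, with a stated time of 48 h; on this read-out lower numbers stand for higher toxicity in this test and higher numbers for lower toxicity in this test: compound 2 gives 4900 nM. Compound 1 `CCc1ccc2[nH]c(=O)c(CN(Cc3ccc(F)cc3)Cc3ccc(C(C)(C)C)cc3)cc2c1` reaches only a limit in this assay, > 33000 nM. Compound 3 `Cc1ccc2[nH]c(=O)c(CN(Cc3ccc(C(C)(C)C)cc3)[C@H](C)c3ccc(F)cc3)cc2c1` is not yet measured; it differs from compound 2 by 1-(4-fluorophenyl)ethyl in place of 4-hydroxybenzyl on an amine nitrogen. Within the data shown here, no step between measured compounds has been computed. Given that compound 1 likewise lacks the 4-hydroxybenzyl group and sits at the limit of > 33000 nM in this assay, at which 1 of the 2 values shown sits, a step toward lower toxicity, beyond the scatter, is expected a 5.1-fold higher number from compound 2 to compound 3 (0.71 log units; beyond the scatter). Compound 3 is estimated at 25000 nM, in the range 8000 nM to 60000 nM, with a fair chance that this assay again reports only a limit.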

Compound 3, half-maximal cytotoxic concentration: > 5000 nM
Compound 3 gave a limit, no number; the forecaster's own chance of this, stated with the estimate: 45%; the middle value lies beyond the limit too.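

In this assay compound 3 reaches only a limit, > 5000 nM. Putting 1-(4-fluorophenyl)ethyl in place of 4-hydroxybenzyl on an amine nitrogen gives an at least 1.0-fold higher number from compound 2 to compound 3 (0.00 log units; that floor lies within the scatter), so a real change in the number is neither shown nor excluded. Within the data shown here, this is the first step readable at this position, and it fixes only a floor, not a size.

On these data alone, how far the number of compound 3 truly lies from that of compound 2 stays open. So does the reading in this assay of an aminobenzyl or carboxybenzyl group on this amine nitrogen.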